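The source may hold more compounds than are shown below. What is called first, only, known or untested is meant among the compounds shown, and "the series" means these compounds.

The series shares the core of compound 1 `COc1ccc(N/C(CCNC2=CC(=O)c3ccccc3C2=O)=N\S(=O)(=O)c2ccc(C)cc2)cc1`, which in a functional assay on MCF7 cells (Homo sapiens) for cytotoxicity, read by MTT assay, with a stated time of 48 h (on this read-out higher numbers stand for weaker inhibition and lower numbers for stronger inhibition), gives 6030 nM. Compound 2 `Cc1ccc(S(=O)(=O)/N=C(/CCNC2=CC(=O)c3ccccc3C2=O)Nc2ccccc2[N+](=O)[O-])cc1` in this assay gives 3090 nM, and the step between them was a 2.0-fold lower number from compound 1 to compound 2 (0.29 log units; within the scatter). Among the measured compounds shown here, on the two numbers so far compound 2 stands lowest, with compound 1 nearest, the two lying within the scatter of each other, so no order between them is claimed. Compound 3 `Cc1ccc(S(=O)(=O)/N=C(/CCNC2=CC(=O)c3ccccc3C2=O)Nc2cccc(C)c2)cc1` has not yet been measured in this assay. Its change from compound 2 is 3-methylphenyl in place of 2-nitrophenyl on an amine nitrogen. For the measured compounds named here, only one measured step bears on exchanging the group on this amine nitrogen, the one from compound 1 to compound 2, and it stayed within the scatter; accordingly no step beyond the scatter is expected in this assay for compound 3, in either direction. Compound 3 is therefore estimated at 4000 nM, with a range from 1500 nM to 11000 nM. The step this estimate implies is expected to be a 1.3-fold higher number from compound 2 to compound 3 (0.11 log units; within the scatter).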

Compound 3, half-maximal inhibitory concentration: 8120 nM
For compound 3 the middle estimate is 2.0-fold (0.31 log units) below the measured one, within the range that was stated.
By their numbers in this assay, from the lowest: compounds 2, 1 and 3 (each within the scatter of the next, the first and the last beyond it).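

In this assay the group on the amine nitrogen now yields its first step beyond the scatter, with a 2.6-fold higher number from compound 2 to compound 3 (0.42 log units; beyond the scatter) on exchanging 2-nitrophenyl for 3-methylphenyl, so this position does respond to the exchange, though modestly. Among the compounds shown here, the other exchange at this place, with a 1.3-fold higher number from compound 1 to compound 3 (0.13 log units; within the scatter) on going from 4-methoxyphenyl to 3-methylphenyl, stays within the scatter, so only the pair of compound 2 and compound 3 is separated and no full order of the three groups can be given. No measurement at hand explains the step.

The compounds shown leave open whether the step follows the nitro and methyl groups themselves or their numbered places on the phenyl ring, which 3-nitrophenyl or 2-methylphenyl on this nitrogen would separate. Also open, going by these compounds, is how a cyclohexyl or benzyl group would read at this position.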